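A few compounds are considered here, and "the series" means these few. Any claim that something is new, unique, unknown or untested is made for them only; others in the source may bear on it.

Three compounds were tested in an assay on HEK293 cells for inhibition of Voltage-dependent T-type calcium channel subunit alpha-1G (Homo sapiens), read by fluorescence, tested at 10 uM; a higher number here means more inhibition at the concentration tested (going by the name of the read-out), a lower number less inhibition. Compound 1, with the structure `CCCc1nc(-c2ccccc2)c(CNCCN2CCN(c3ccccc3OC)CC2)o1`, gives 39.7%. Compound 2, with the structure `CCCc1nc(-c2ccccc2)c(CNCCN2CCN(c3ccc(C)cc3)CC2)o1`, gives 48.1%. Compound 3, with the structure `CCCc1nc(-c2ccccc2)c(CNCCCN2CCN(c3ccccc3OC)CC2)o1`, gives 41%. All three share the same core; compound 2 differs from compound 1 in one place, namely (4-methylphenyl in place of 2-methoxyphenyl on an amine nitrogen in a ring), and this change gave a number 8.4 percentage points higher from compound 1 to compound 2 (within the scatter). Compound 3 carries the same 2-methoxyphenyl group as compound 1, but the difference between these two cores is not broken down here. The values of compound 1 and compound 3 lie close together, and neither stands apart from compound 2 by more than the usual spread of this kind of measurement.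

Compound 4, with the structure `CCCc1nc(-c2ccccc2)c(CNCCCN2CCN(c3ccc(C)cc3)CC2)o1`, has not yet been measured. It stands to compound 3 as compound 2 stands to compound 1: 4-methylphenyl in place of 2-methoxyphenyl on an amine nitrogen in a ring. The surroundings of the change are the same in both pairs, so this is the same change made a second time on a different core.

Because the earlier change gave a number 8.4 percentage points higher from compound 1 to compound 2 (within the scatter), a step of similar size is expected from compound 3 to compound 4, namely a number 8 percentage points higher from compound 3 to compound 4 (within the scatter). On that basis compound 4 is estimated to give 49% in this assay, with a likely range from 36% to 62%.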

Compound 4, a percentage reported as inhibition, at one concentration (the size of the read-out at that concentration, not a potency): 53.9%
Compound 4: the middle estimate sits 4.9 percentage points below what was measured; the range from low to high includes it.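

In this assay, putting 4-methylphenyl in place of 2-methoxyphenyl on the second core gave a number 12.9 percentage points higher from compound 3 to compound 4 (beyond the scatter), so the change pointed the same way here as on the first core. Set side by side, the two steps agree as closely as repeated measurements of this kind can show: the same change on two cores in this assay, a number 8.4 percentage points higher (within the scatter) from compound 1 to compound 2 and a number 12.9 percentage points higher (beyond the scatter) from compound 3 to compound 4, 4.5 percentage points apart, within the scatter of two such steps

Going by these compounds alone, this supports carrying the change across these two cores, with a similar size of step on each, but it rests on only two pairs of compounds, only one of which stands clear of the scatter, and so it does not show that the change would behave alike on any other core, and it speaks only of a stronger effect at this one concentration.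

The compounds shown leave open whether the step comes from losing the 2-methoxyphenyl group or from gaining the 4-methylphenyl group, which a plain phenyl, a 2-methylphenyl or a 4-methoxyphenyl group on the same ring nitrogen could help to separate. They also leave open whether the step would hold with a longer chain joining the two amine nitrogens.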